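Swapping the sulfonyl aryl group on a shared anilino-pyrimidine core

This account rests on a few compounds, and the source may have more. Where it says the series, first, only, none or still open, it means among the compounds named here.

Compound 1 `Cc1ccc(NS(=O)(=O)c2ccc(Cl)cc2)cc1Nc1nccc(-c2cccnc2)n1`: 10200 nM
Compound 2 `Cc1ccc(NS(=O)(=O)c2ccc(-c3ccccc3)cc2)cc1Nc1nccc(-c2cccnc2)n1`: 9490 nM
Compound 3 `COc1cc(-c2ccnc(Nc3cc(NS(=O)(=O)c4ccc(-c5ccccc5)cc4)ccc3C)n2)cc(OC)c1OC`: 5600 nM

Three compounds share one core and differ at two places. In a functional assay on K562 cells (Homo sapiens) for cytotoxicity, read by MTT assay, with a stated time of 24 h (a lower number here means a stronger inhibitor, a higher number a weaker inhibitor), compound 1 gives 10200 nM, compound 2 gives 9490 nM and compound 3 gives 5600 nM. Compound 3 sits at the low end of these three numbers, but its gaps to compound 2 and to compound 1 both lie within the scatter, so the three are not separated. The step of a 1.1-fold lower number from compound 1 to compound 2 (0.03 log units; within the scatter) and the step of a 1.7-fold lower number from compound 2 to compound 3 (0.23 log units; within the scatter) were each within the scatter.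

Compound 4 `COc1ccc(S(=O)(=O)Nc2ccc(C)c(Nc3nccc(-c4cc(OC)c(OC)c(OC)c4)n3)c2)cc1OC` has not yet been measured in this assay. It differs from compound 3 by 3,4-dimethoxyphenyl in place of 4-phenylphenyl on a sulfonyl sulfur. Among the compounds with values here, the only measured step at the same place, a 1.1-fold lower number from compound 1 to compound 2 (0.03 log units; within the scatter), was within the scatter, and the change from compound 2 to compound 3 elsewhere on the core was too; nothing here points to a large move. Compound 4 is therefore expected to stay near compound 3, with a step of a 1.2-fold higher number from compound 3 to compound 4 (0.06 log units; within the scatter). The estimate for compound 4 in this assay is 6500 nM, with a range from 2500 nM to 17000 nM.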

Compound 4, half-maximal inhibitory concentration: 8570 nM
Compound 4: middle estimate off by 1.3-fold (0.12 log units), on the low side, within the range that was stated.
By their numbers in this assay, from the lowest: compounds 3, 4, 2 and 1 (each within the scatter of the next).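

In this assay the exchange on the sulfonyl sulfur gives a 1.5-fold higher number from compound 3 to compound 4 (0.18 log units; within the scatter) with the 3,4,5-trimethoxyphenyl group on the core. The earlier step at this place involved chloro and phenyl with pyridin-3-yl on the core, whereas this one shows that a single ring carrying two methoxy groups can replace 4-phenylphenyl, with its two carbon-only rings, without a step beyond the scatter. The data shown give no reason for this outcome.

No step at this place has yet gone beyond the scatter, so the compounds shown do not reveal which sulfonyl aryl groups, if any, would separate from the rest. On these data alone, how an amine or a carboxylic acid on that aryl ring would read in this assay remains open.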